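Working notes: the step from compound 3 to compound 4

A few compounds are considered here, and "the series" means these few. Any claim that something is new, unique, unknown or untested is made for them only; others in the source may bear on it.

Measured so far in an ADME assay on liver (Homo sapiens) for metabolic stability, read by LC-MS, using microsomes and NADPH (a higher number here means that more of the compound is left, a lower number that less of the compound is left), for three compounds:
- compound 1 `CCCN(Cc1ccc(OCCN2C(=O)CCC2=O)c(C)c1)[C@@H](CC(=O)O)c1ccc(Cl)cc1` gives 97%
- compound 2 `Cc1cc(CN(CC2CCCCC2)C(CC(=O)O)c2ccc(Cl)cc2)ccc1OCCN1C(=O)CCC1=O` gives 47%
- compound 3 `COc1cc(CN(CC(C)C)C(CC(=O)O)c2ccc3c(c2)CCO3)ccc1OCCN1C(=O)CCC1=O` gives 92%

Compound 3 lies within the scatter of compound 1 and beyond the scatter above compound 2. Compound 4 `COc1cc(CN(CC(C)C)C(CC(=O)O)c2ccc(Cl)cc2)ccc1OCCN1C(=O)CCC1=O` is not yet measured. The change to it is a group of 7 heavy atoms (6 carbon, 1 chlorine; one six-membered aromatic ring of carbon only) in place of a group of 9 heavy atoms (8 carbon, 1 oxygen; one five-membered non-aromatic ring with 1 hetero atom, one six-membered aromatic ring of carbon only), on a saturated chain carbon bound to an amine nitrogen and a saturated chain carbon on a saturated chain carbon bound to an amine nitrogen and a saturated chain carbon, and the group that enters is 4-chlorophenyl. For the measured compounds named here, no measured pair isolates this change. The 4-chlorophenyl group is also carried by compound 1 at 97% and by compound 2 at 47% so that group alone does not settle the outcome, and these two compounds also differ from compound 4 elsewhere. No shift beyond the scatter is expected in this assay and the expected a number 6 percentage points lower from compound 3 to compound 4 (within the scatter) is a small fall. The estimate for compound 4 is 86% with an expected range from 65% to 97% in repeat measurements.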

Compound 4, percent of the compound remaining: 80%
Compound 4: middle estimate off by 6 percentage points, on the high side; the range from low to high includes it.
By their numbers in this assay, from the lowest: compound 2; then compound 4; then compounds 3 and 1 (each within the scatter of the next).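

In this assay, replacing the group with the five-membered non-aromatic ring by 4-chlorophenyl, on a saturated chain carbon bound to an amine nitrogen and a saturated chain carbon, gives a number 12 percentage points lower from compound 3 to compound 4 (beyond the scatter). For the compounds shown here, this is the first reading of this position on its own, since the earlier compounds differ from one another in more than one place, and it shows that this change alone moves the percent remaining, though only modestly. No available measurement bears on what lies behind the step.

The compounds shown leave open how other groups at this position would read, such as a pyridine ring or a 4-fluorophenyl group. They also leave open whether the same change gives a step of similar size when a different chain, such as a linear butyl chain, sits on the amine nitrogen.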